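The source may report more compounds than this note shows. Statements on the series, on what has been measured and on what is new or still open speak of the compounds shown alone.

Of the compounds shown here, three built on one shared core have been measured in a functional assay on A549 cells (Homo sapiens) for cytotoxicity, read by MTT assay, with a stated time of 72 h; a lower number here means a stronger inhibitor, a higher number a weaker inhibitor. Compound 1 `CN(C)CCn1cnnc1-c1cc(Oc2ccc(NC(=O)N/N=C/c3c[nH]c4ccccc34)cc2F)ccn1` gives 820 nM, compound 2 `CN(C)CCn1cnnc1-c1cc(Oc2ccc(NC(=O)N/N=C/c3ccc(O)c(Br)c3)cc2F)ccn1` gives 1370 nM, and compound 3 `CN(C)CCn1cnnc1-c1cc(Oc2ccc(NC(=O)N/N=C/c3ccc(F)cc3)cc2F)ccn1` gives 1790 nM. Going by the values given here, compound 3 stands at the high end of these numbers, yet only the step of a 2.2-fold higher number from compound 1 to compound 3 (0.34 log units; beyond the scatter) is beyond the scatter, while a 1.7-fold higher number from compound 1 to compound 2 (0.22 log units; within the scatter) and a 1.3-fold higher number from compound 2 to compound 3 (0.12 log units; within the scatter) are within it. Compound 4 `CN(C)CCn1cnnc1-c1cc(Oc2ccc(NC(=O)N/N=C/c3ccc(F)cc3F)cc2F)ccn1` differs from compound 3 by fluoro in place of hydrogen on an aromatic carbon. Among the compounds with values here, no measured step bears directly on this change: each of the three swaps the whole aromatic group on the carbon with a double bond to nitrogen, and even those swaps reach at most a modest step. The step of a 1.0-fold higher number from compound 3 to compound 4 (0.00 log units; within the scatter) is therefore expected to be none beyond the scatter. Compound 4 is estimated at 1800 nM, within 900 nM to 3600 nM.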

Compound 4, half-maximal inhibitory concentration: 1870 nM
The estimate for compound 4 lay 1.0-fold (0.02 log units) below the measured number; the measured number falls inside the stated range.
By their numbers in this assay, from the lowest: compounds 1, 2, 3 and 4 (each within the scatter of the next, the first and the last beyond it).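

Fluoro in place of hydrogen on this aromatic carbon, ortho to a large group, is compared directly here for the first time, and in this assay the step is a 1.0-fold higher number from compound 3 to compound 4 (0.02 log units; within the scatter) and shows no separation between 4-fluorophenyl and 2,4-difluorophenyl. The 2,4-difluorophenyl group also stands close to 3-bromo-4-hydroxyphenyl with a 1.4-fold higher number from compound 2 to compound 4 (0.14 log units; within the scatter) and apart from 1H-indol-3-yl only modestly with a 2.3-fold higher number from compound 1 to compound 4 (0.36 log units; beyond the scatter) as printed. Nothing measured here offers an explanation for these results. The compounds shown leave open whether a methoxy group or an amine on this same carbon would separate from hydrogen. Only hydrogen and fluoro are compared there.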